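A few compounds are considered here, and "the series" means these few. Any claim that something is new, unique, unknown or untested is made for them only; others in the source may bear on it.

Compound 1 `Cn1nc(-c2ccccc2)c2c1OC(N)=C(C#N)C2c1ccccc1` in a functional assay on NCI-H2122 cells (Homo sapiens) for inhibition, read by microscopy, with a stated time of 10 days (on this read-out higher numbers stand for weaker inhibition and lower numbers for stronger inhibition), gives > 10000 nM, a limit of the assay and not a number.
Compound 2 `Cn1nc(-c2ccccc2)c2c1OC(N)=C(C#N)C2c1ccc(F)cc1` in this assay gives > 10000 nM, likewise a limit.
Compound 3 `Cn1nc(-c2ccccc2)c2c1OC(N)=C(C#N)C2c1cc(F)cc(F)c1` in this assay gives 6600 nM.

Compound 3 therefore stands alone as the only one of the three with a number in this assay; the other two rest at the limit of > 10000 nM in this assay, at which 2 of the 3 values shown sit. The steps that reach it, an at least 1.5-fold lower number from compound 1 to compound 3 (0.18 log units; that floor lies within the scatter) and an at least 1.5-fold lower number from compound 2 to compound 3 (0.18 log units; that floor lies within the scatter), are floors only, and each floor lies within the scatter.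

Compound 4 `COc1ccc(C2C(C#N)=C(N)Oc3c2c(-c2ccccc2)nn3C)cc1` differs from compound 3 in one place: 4-methoxyphenyl in place of 3,5-difluorophenyl on a saturated ring carbon. The measured steps that bear on it are the two just named, both ending at compound 3, and both say only that the 3,5-difluorophenyl gave a lower number than phenyl or 4-fluorophenyl by an unreadable margin. The 4-methoxyphenyl of compound 4 carries a single substituent, as the 4-fluorophenyl of compound 2 does, and compound 2 sat at the limit. The number for compound 4 is thus expected to rise from that of compound 3, quite possibly back to the limit. For compound 4 the estimate is 12000 nM, within a range from 4000 nM to 35000 nM. That estimate means an expected step of a 1.8-fold higher number from compound 3 to compound 4 (0.26 log units; within the scatter).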

Compound 4, half-maximal inhibitory concentration: > 10000 nM
Compound 4: only a limit was reported; the forecaster's own chance of this, stated with the estimate: 60%; the middle value is on the limit's open side.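

With the 4-methoxyphenyl, which brings one hydrogen-bond acceptor where the 3,5-difluorophenyl has none, compound 4 also returns only a limit of the assay and not a number in this assay, so a third group on this saturated ring carbon ends at that limit: the limit of > 10000 nM in this assay, at which 3 of the 4 values shown sit. For the compounds shown here, the change from the 3,5-difluorophenyl can be read only as a floor, an at least 1.5-fold higher number from compound 3 to compound 4 (0.18 log units; that floor lies within the scatter), and compound 3 remains the only compound here with a number. The steps from compound 1 and from compound 2 to compound 4 cannot be read, as both ends of each are limits.

On these data alone, how far the three limit compounds lie from compound 3 stays open. Also open, as far as these compounds go, is what a chloro, a trifluoromethyl or an amine on this aromatic ring would give, or a cyclohexyl group in its place.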